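This account rests on a few compounds, and the source may have more. Where it says the series, first, only, none or still open, it means among the compounds named here.

In an ADME assay on MDBK cells (Bos taurus) for cytotoxicity, read by MTT assay, with a stated time of 96 h (on this read-out lower numbers stand for higher toxicity in this test and higher numbers for lower toxicity in this test), compound 1 (`CC(=O)c1ccc2c(c1)nc(-c1ccoc1)n2C1CCCCC1`) gives > 100000 nM as a limit. Compound 2 (`CC(=O)c1ccc2[nH]c(-c3ccoc3)nc2c1`) gives >= 100000 nM as a limit too. For the measured compounds named here, the one measured step (a step that the two limits leave unreadable from compound 1 to compound 2) has no readable size and concerns hydrogen in place of cyclohexyl on an aromatic nitrogen, so it offers little guidance here. Compound 3 (`C/C(=N\NC(N)=S)c1ccc2c(c1)nc(-c1ccoc1)n2C1CCCCC1`) instead changes the aromatic carbon that carries the acetyl in compound 1 (a group of 7 heavy atoms (3 carbon, 3 nitrogen, 1 sulfur; no ring) in place of a group of 3 heavy atoms (2 carbon, 1 oxygen; no ring), on an aromatic carbon). Going by the values given here, with no measured step at this place, only a modest move toward higher toxicity in this test is expected, and the estimated step (an at least 2.0-fold lower number from compound 1 to compound 3 (0.30 log units; that floor lies within the scatter)) is uncertain. Compound 3 is estimated at 50000 nM with an expected range from 12000 nM to 100000 nM in this test.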

Compound 3, half-maximal cytotoxic concentration: > 100000 nM
Compound 3: a limit, no number; the forecaster's own chance of this, stated with the estimate: 40%; middle value at least 2.0-fold (0.30 log units) from the limit.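

Compound 1 and compound 3 both stand as limits in this assay, so the step between them cannot be read. With no number among them, the compounds shown leave open whether replacing the acetyl or the cyclohexyl shifts this read-out at all.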